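A few compounds are considered here, and "the series" means these few. Any claim that something is new, unique, unknown or untested is made for them only; others in the source may bear on it.

Measured so far:
- compound 1, `CCOC(=O)C(=O)Nc1nc2ccc(NC(=O)c3ccccc3)cc2s1`: > 50000 nM
- compound 2, `CCOC(=O)C(=O)Nc1ccc2nc(NC(=O)c3cc4cc(C)ccc4[nH]3)sc2c1`: 10100 nM

Of the compounds shown here, two sharing one core have been tested in a functional assay on MCF7 cells (Homo sapiens) for antiproliferative activity; on this read-out lower numbers stand for an effect already at smaller amounts and higher numbers for an effect only at larger amounts of compound. Compound 1, `CCOC(=O)C(=O)Nc1nc2ccc(NC(=O)c3ccccc3)cc2s1`, reaches only a limit of the assay, > 50000 nM, so no number is known for it. Within the data shown here, compound 2, `CCOC(=O)C(=O)Nc1ccc2nc(NC(=O)c3cc4cc(C)ccc4[nH]3)sc2c1`, is the one compound with an actual number, giving 10100 nM in this assay. Among the measured compounds shown here, it therefore stands as the only value that can be compared against anything; the remaining entry sits at the limit of > 50000 nM in this assay, at which 1 of the 2 values shown sits.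

Compound 3, `CCOC(=O)C(=O)Nc1ccc2nc(NC(=O)c3cc4ccccc4[nH]3)sc2c1`, has not yet been tested. It differs from compound 2 by hydrogen in place of methyl on an aromatic carbon. For the measured compounds named here, that is a small change, and no measured pair shows what such a change does in this assay. The expected step of a 1.2-fold higher number from compound 2 to compound 3 (0.07 log units; within the scatter) is none beyond the usual scatter, perhaps leaning toward a slightly weaker effect. Compound 3 is therefore estimated to give about 12000 nM in this assay, most likely between 5000 nM and 30000 nM.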

Compound 3, half-maximal effective concentration: 8990 nM
The estimate for compound 3 lay 1.3-fold (0.13 log units) above the measured number; the measured number falls inside the stated range.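

In this assay, among these compounds, the change from 5-methyl-1H-indol-2-yl to 1H-indol-2-yl now has a measured size, which the earlier compounds could not give: a 1.1-fold lower number from compound 2 to compound 3 (0.05 log units; within the scatter). Compound 2 and compound 3 therefore cannot be told apart in this read-out, so the methyl on this aromatic carbon, meta to a fused ring and para to a fused ring, can be replaced by hydrogen without a difference that stands out from repeated measurements. Compound 1 still offers only a limit and not a number, so it gives no measured value to set beside this pair: the limit of > 50000 nM in this assay, at which 1 of the 3 values shown sits.

From the compounds shown here alone, this single pair covers only methyl and hydrogen, so it remains open whether a methoxy group, a chlorine atom, an amine or a carboxylic acid on the same aromatic carbon would shift the number beyond the usual scatter. Going by these compounds, compound 2 and compound 3 also share the ethyl ester, so what a carboxylic acid or an amide in its place would do in this assay remains open as well.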